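The compounds below may be only part of what the source reports. "The series", "measured", "known", "first", "only" and "open" are said of these compounds alone.

Measured compounds:
Compound 1 `Cn1c(-c2ccccc2)nc2c(NC3CCCC3)ncnc21` in an assay on CHO cells for displacement of a labelled ligand from adenosine receptor A3 (Homo sapiens), read by scintillation counting, with a stated time of 3 h (a lower number here means a stronger inhibitor, a higher number a weaker inhibitor), gives 846 nM.
Compound 2 `Cn1c(-c2ccc(F)cc2)nc2c(NC3CCCC3)ncnc21` in this assay gives 1140 nM.

Among the measured compounds shown here, of the two numbers in hand, compound 1 has the smaller one, but its only neighbour is compound 2, and the step of a 1.3-fold higher number from compound 1 to compound 2 (0.13 log units; within the scatter) lies within the scatter, so the two compounds cannot be separated. Compound 3 `Cn1c(-c2ccccc2)nc2c(NC3CCCCC3)ncnc21` has not yet been measured in this assay. It differs from compound 1 by cyclohexyl in place of cyclopentyl on a nitrogen on an aromatic ring. For the measured compounds named here, no measured step bears on this change: the one known step concerns a fluoro in place of hydrogen on an aromatic carbon, a different part of the molecule, and it stayed within the scatter. The data therefore give no direction for the ring change. Compound 3 is accordingly expected to give a number close to that of compound 1, with the step of a 1.2-fold higher number from compound 1 to compound 3 (0.07 log units; within the scatter) expected to stay within the scatter. The estimate for compound 3 is 1000 nM, with a range from 300 nM to 3500 nM.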

Compound 3, inhibition constant: 2370 nM
For compound 3 the middle estimate is 2.4-fold (0.37 log units) below the measured one, and the stated range covers the measured number.
By their numbers in this assay, from the lowest: compounds 1 and 2 (each within the scatter of the next); then compound 3.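

Cyclohexyl in place of cyclopentyl on a nitrogen on an aromatic ring (a 2.8-fold higher number from compound 1 to compound 3 (0.45 log units; beyond the scatter)) is the first change shown to move the number in this assay beyond the scatter, and it moves it toward a weaker inhibitor. This nitrogen substituent therefore registers in the assay, even though the step is modest, whereas the fluoro step (a 1.3-fold higher number from compound 1 to compound 2 (0.13 log units; within the scatter)) left its two compounds inseparable. Nothing in the available evidence explains why the six-membered ring gives the higher number.

As far as these compounds go, how a cyclobutyl or cycloheptyl group, or an open chain such as isopropyl, would read on this nitrogen stays open. From the compounds shown here alone, it is also open whether fluoro in place of hydrogen on an aromatic carbon would read the same with cyclohexyl on the nitrogen.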